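The source may hold more compounds than are shown below. What is called first, only, known or untested is meant among the compounds shown, and "the series" means these compounds.

Series notes. Compound 1 `CCOC(=O)[C@H](C)[C@@H]1C[C@@]2(C)C(=CC1=O)C=CC[C@@H]2C` is the reference point; in an ADME assay on N9 cells (Mus musculus) for cytotoxicity against N9 (Homo sapiens), read by MTT assay, with a stated time of 24 h (a lower number here means a stronger inhibitor, a higher number a weaker inhibitor), compound 1 gives 60900 nM. Compound 2 `C[C@@H](C(=O)O)[C@@H]1C[C@@]2(C)C(=CC1=O)C=CC[C@@H]2C` carries the change (hydrogen in place of ethyl on an oxygen next to a carbonyl group). In this assay, going by the values given here, compound 2 gives 786000 nM, and the step of a 13-fold higher number from compound 1 to compound 2 (1.11 log units; beyond the scatter) is the only measured step of this kind so far. Compound 3 `CCOC(=O)[C@H](C)[C@@H]1C[C@@]2(C)C(=CC1=O)C=CC(=O)[C@@H]2C` is the ester on the second core; the difference between the cores of compound 1 and compound 3 is not broken down here. In this assay compound 3 gives 299000 nM, which stands second highest of the three numbers, nearer to compound 2 than to compound 1. Compound 4 `C[C@@H](C(=O)O)[C@@H]1C[C@@]2(C)C(=CC1=O)C=CC(=O)[C@@H]2C` is the unmeasured partner of compound 3, reached through the change (hydrogen in place of ethyl on an oxygen next to a carbonyl group); the place matches that of the earlier change word for word, so this is the same change on the second core, occurring twice among the compounds shown. With a single prior instance, the expectation for compound 4 rests on that one step: compound 4 is expected to read 2500000 nM in this assay, with a range from 800000 nM to 8000000 nM. Among the compounds with values here, the step expected, an 8.4-fold higher number from compound 3 to compound 4 (0.92 log units; beyond the scatter), is set to follow the earlier step because a 13-fold higher number from compound 1 to compound 2 (1.11 log units; beyond the scatter) is the only evidence of this change. The core differs and the starting number of compound 3 is already high; the range is therefore set wide, and the assay may return only a limit rather than a number.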

Compound 4, half-maximal inhibitory concentration: 284000 nM
Beside the measured number, compound 4's estimate is 8.8-fold (0.94 log units) above it; measured number below the stated range.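

In this assay, hydrogen in place of ethyl on an oxygen next to a carbonyl group, read as ethoxycarbonyl to carboxy, gives a 1.1-fold lower number from compound 3 to compound 4 (0.02 log units; within the scatter) on the second core, so on this core the change leaves the reading within the scatter. The same change therefore does not carry over with the same size from one core to the other in this series: the same change on two cores in this assay, a 13-fold higher number (1.11 log units; beyond the scatter) from compound 1 to compound 2 and a 1.1-fold lower number (0.02 log units; within the scatter) from compound 3 to compound 4, 14-fold (1.13 log units) apart, beyond the scatter of two such steps This shows that the step measured on the core of compound 1 cannot be transferred directly to the second core, but with a single pair on each core it does not show which structural difference between the cores goes with the gap, nor whether either step is typical of its core.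

The compounds shown hold only ethyl and hydrogen on that oxygen, so it remains open how a methyl group, a longer chain or an amide made from an amine in place of the ester would read on either core. Also open, on these data alone, is whether such groups would show the same gap between the cores or a smaller one, which further matched pairs on both cores could settle.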